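The source may report more compounds than this note shows. Statements on the series, on what has been measured and on what is new or still open speak of the compounds shown alone.

Compound 1 `Cc1ccc(S(=O)(=O)c2nc3ccccc3nc2Nc2ccc(C(F)(F)F)cc2)cc1`: 2540 nM
Compound 2 `O=S(=O)(c1ccc(Br)cc1)c1nc2ccccc2nc1Nc1cccc(O)c1`: 1700 nM

Of the compounds shown here, two have been measured in a functional assay on PC-3 cells (Homo sapiens) for cytotoxicity, read by MTT assay, with a stated time of 72 h; a lower number here means a stronger inhibitor, a higher number a weaker inhibitor. Compound 2 gives 1700 nM in this assay, and compound 1 gives 2540 nM; the gap between the two lies within the usual scatter of repeated measurements, so they cannot be told apart on these numbers. Compound 3 `O=S(=O)(c1ccc(Br)cc1)c1nc2ccccc2nc1Nc1ccc(C(F)(F)F)cc1` has not yet been measured. It differs from compound 2 in one place: 4-(trifluoromethyl)phenyl in place of 3-hydroxyphenyl on a nitrogen on an aromatic ring. Among the compounds with values here, no step between measured compounds that differ in one place is available, so the size of this change has to be guessed. Compound 1, which carries the same 4-(trifluoromethyl)phenyl group, gives 2540 nM, a number close to that of compound 2. Compound 3 is therefore expected to give 2200 nM in this assay, with a range of 1000 nM to 5000 nM. The step from compound 2 to compound 3 is expected to be a 1.3-fold higher number from compound 2 to compound 3 (0.11 log units; within the scatter), within the scatter.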

Compound 3, half-maximal inhibitory concentration: 4150 nM
Compound 3: the middle estimate sits 1.9-fold (0.28 log units) below what was measured, and the stated range covers the measured number.
By their numbers in this assay, from the lowest: compounds 2, 1 and 3 (each within the scatter of the next, the first and the last beyond it).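

In this assay, within the data shown here, with the bromo group held fixed, placing 4-(trifluoromethyl)phenyl instead of 3-hydroxyphenyl on the nitrogen gives a 2.4-fold higher number from compound 2 to compound 3 (0.39 log units; beyond the scatter), the first step at this position, modest in size but beyond the scatter. With 4-(trifluoromethyl)phenyl held fixed, bromo in place of methyl on an aromatic carbon gives a 1.6-fold higher number from compound 1 to compound 3 (0.21 log units; within the scatter), which lies within the scatter, so that swap cannot be told from no change on these numbers. No measurement here explains the step at the nitrogen.

As far as these compounds go, the step at the nitrogen rests on a single pair, so whether it keeps its size with methyl in place of bromo remains open. Also open, from the compounds shown here alone, is what a plain phenyl or an aminophenyl group would give on that nitrogen.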